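A few compounds are considered here, and "the series" means these few. Any claim that something is new, unique, unknown or untested is made for them only; others in the source may bear on it.

Measured so far:

compound 1, `Cc1cc(NC(=O)Nc2ccc(C(C)(C)C)cc2)c2ccccc2n1` — > 25000 nM
compound 2, `Cc1cc(NC(=O)Nc2ccccc2C(N)=O)c2ccccc2n1` — > 25000 nM
compound 3, `Cc1cc(NC(=O)Nc2cccc3nsnc23)c2ccccc2n1` — > 25000 nM

All three values come from an ADME assay on HEK293 cells (Homo sapiens) for cytotoxicity, with a stated time of 72 h; a higher number here means that more compound is needed for the effect, a lower number that less compound is needed. For compound 1 the value > 25000 nM is a limit of the assay and not a number. For compound 2 the value > 25000 nM is likewise a limit. For compound 3 the value > 25000 nM is also a limit. Among the measured compounds shown here, compound 1 thus stands at the same limit as the two other measured compounds, with no number to place it above or below them; the one point of evidence across the set is the limit of > 25000 nM in this assay, at which 3 of the 3 values shown sit.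

The compound to be measured next is compound 4, `Cc1cc(NC(=O)Nc2ccc(OC(F)(F)F)cc2)c2ccccc2n1`. It differs from compound 1 in one place: trifluoromethoxy in place of tert-butyl on an aromatic carbon. For the measured compounds named here, no step between measured compounds exists to calibrate what this change does in this assay; every measured value sits at the limit.

On that basis, the step from compound 1 to compound 4 is expected to be none beyond the scatter, and most likely the assay will again report only a limit. Compound 4 is expected to give 30000 nM, with a range of 15000 nM to 80000 nM, meaning an expected step that the limit leaves unreadable from compound 1 to compound 4.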

Compound 4, half-maximal effective concentration: 14000 nM
Compound 4: middle estimate off by 2.1-fold (0.33 log units), on the high side, outside the stated range (below it).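

In this assay compound 4 gives 14000 nM, the only value among those shown that is a number and not a limit of the assay. At this position, on an aromatic carbon para to a large group, trifluoromethoxy in place of tert-butyl gives an at least 1.7-fold lower number from compound 1 to compound 4 (0.25 log units; that floor lies within the scatter), and this is only a floor, so the full size of the step stays unread. The position can therefore carry a change that brings a compound onto a readable value in this assay, which compound 1, compound 2 and compound 3 could not show, each of them being held at the same limit: the limit of > 25000 nM in this assay, at which 3 of the 4 values shown sit.

With a single readable value, no trend across groups at this position can be stated, and it remains unclear whether the shift goes with trifluoromethoxy in particular or would appear with other groups in this place. A carboxylic acid, an amine or a plain methoxy group on the same aromatic carbon would show whether readable values in this assay are common here or confined to compound 4.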